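Adding a Methyl Group to Two Weak Cytotoxic Compounds

The source may hold more compounds than are shown below. What is called first, only, known or untested is meant among the compounds shown, and "the series" means these compounds.

Measured compounds:
- compound 1 `Nc1nc(-c2ccccc2)cn1/N=C/c1cc2ccccc2nc1Cl`: in a functional assay on MDA-MB-231 cells (Homo sapiens) for cytotoxicity, read by MTT assay, with a stated time of 48 h (a lower number here means a stronger inhibitor, a higher number a weaker inhibitor), compound 1 gives 49000 nM
- compound 2 `Cc1ccc(-c2cn(/N=C/c3cc4ccccc4nc3Cl)c(N)n2)cc1`: in this assay compound 2 reaches only a limit of the assay, > 50000 nM
- compound 3 `Nc1nc(-c2cccc3ccccc23)cn1/N=C/c1cc2ccccc2nc1Cl`: in this assay compound 3 likewise reaches only a limit of the assay, > 50000 nM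

Compound 1 and compound 2 differ by one change, (methyl in place of hydrogen on an aromatic carbon). The step it made is an at least 1.0-fold higher number from compound 1 to compound 2 (0.00 log units; that floor lies within the scatter), so the two values cannot be told apart.

Compound 3 carries a different group on the shared core; the difference between the two cores is not broken down here.

Compound 4 `Cc1ccc2nc(Cl)c(/C=N/n3cc(-c4cccc5ccccc45)nc3N)cc2c1` is not yet measured. It differs from compound 3 by methyl in place of hydrogen on an aromatic carbon. This is the same kind of change as that from compound 1 to compound 2, but not the same: in compound 2 the methyl sits on a six-membered aromatic ring of carbon only, para to a large group, whereas in compound 4 it sits on a six-membered aromatic ring of carbon only that is part of a fused or bridged system of two rings, meta to a fused ring and para to a fused ring.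

Among the measured compounds shown here, compound 3 sits at the limit of > 50000 nM in this assay, at which 2 of the 3 values shown sit, and the one measured methyl step stayed within the scatter, so compound 4 is expected to remain weak, with an estimated step that the limit leaves unreadable from compound 3 to compound 4. The estimate for compound 4 in this assay is 60000 nM, expected between 30000 nM and 150000 nM.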

Compound 4, half-maximal inhibitory concentration: > 50000 nM
Compound 4: only a limit was reported; the forecaster's own chance of this, stated with the estimate: 75%; the middle value lies beyond the limit too.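

In this assay compound 4 reaches only a limit of the assay, > 50000 nM. Compound 3 also stands at a limit, so no step can be read between compound 3 and compound 4, and most of the series now sits at the same ceiling: the limit of > 50000 nM in this assay, at which 3 of the 4 values shown sit. The compounds shown leave open how strong compound 2, compound 3 and compound 4 really are, and whether either methyl changes cytotoxicity at all.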